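The source may report more compounds than this note shows. Statements on the series, on what has been measured and on what is new or still open speak of the compounds shown alone.

Two members of the series have been measured in a physicochemical assay for solubility, read by nephelometry, at pH 7.4; on this read-out lower numbers stand for lower solubility and higher numbers for higher solubility. Compound 1 `COc1cccc(NC(=O)c2nnn(Cc3ccc(C(C)C)cc3)c2N)c1` gives 14000 nM, the lower of the two numbers. Compound 2 `COc1cccc(NC(=O)c2nnn(CC3CCN(C(=O)OC(C)(C)C)CC3)c2N)c1` gives 39000 nM, which stands beyond the scatter from compound 1. The next compound, compound 3 `COc1cccc(NC(=O)c2nnn(Cc3ccc(C4CC4)cc3)c2N)c1`, carries cyclopropyl in place of isopropyl on an aromatic carbon. Among the measured compounds shown here, no measured pair shows this exchange, so the expectation rests on compound 1 alone and on the small size of the change. Only a small step is expected, a 1.1-fold higher number from compound 1 to compound 3 (0.06 log units; within the scatter), not beyond the scatter in either direction. For compound 3 the estimate is 16000 nM, with a range from 7000 nM to 38000 nM.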

Compound 3, solubility: 79000 nM
Beside the measured number, compound 3's estimate is 4.9-fold (0.69 log units) below it; measured number above the stated range.
By their numbers in this assay, from the lowest: compound 1; then compound 2; then compound 3.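

In this assay cyclopropyl in place of isopropyl on the aromatic carbon para to a large group gives a 5.6-fold higher number from compound 1 to compound 3 (0.75 log units; beyond the scatter). Among the compounds shown here, this is the first comparison that differs in one place only, and it shows that this position can shift the read-out beyond the scatter even when the group that enters has the same count of heavy atoms as the group that leaves. Nothing at hand bears on the origin of this step.

Going by these compounds, whether cyclobutyl, an amine or a carboxylic acid at this place would move the number further remains open. So does whether the same exchange gives a similar step on another core.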